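The source may report more compounds than this note shows. Statements on the series, on what has been measured and on what is new or still open speak of the compounds shown alone.

Values in a functional assay on SK-OV-3 cells (Homo sapiens) for inhibition, read by CCK-8 assay, with a stated time of 70 h; a lower number here means a stronger inhibitor, a higher number a weaker inhibitor:
Compound 1 `Nc1ccc(COc2ccc(OCCOCCNC3CCCC3)cc2)cc1`: 31700 nM
Compound 2 `Cc1ccc(COc2ccc(OCCOCCNC3CCCC3)cc2)cc1`: 17200 nM
Compound 3 `CCOc1ccc(OCCOCCNC2CCCC2)cc1`: 90500 nM

Compound 3 is the weakest inhibitor of the three, with the highest number. Compound 4 `c1ncn(-c2ccc(OCCOCCNC3CCCC3)cc2)n1` carries 1H-1,2,4-triazol-1-yl in place of ethoxy on an aromatic carbon. Two steps change the same ethoxy group: a 2.9-fold higher number from compound 1 to compound 3 (0.46 log units; beyond the scatter) and a 5.3-fold higher number from compound 2 to compound 3 (0.72 log units; beyond the scatter). Both are modest, and in both the compound lacking an aromatic ring in that group has the higher number. The step of a 1.8-fold lower number from compound 1 to compound 2 (0.27 log units; within the scatter) shows no separation between those two ring-bearing groups. Among the measured compounds shown here, no measured compound carries the triazolyl group, so the direction remains tentative in this assay. A modest change towards a lower number is expected, and the estimated step is a 1.8-fold lower number from compound 3 to compound 4 (0.26 log units; within the scatter). The estimate for compound 4 is 50000 nM, with an expected range of 20000 nM to 120000 nM.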

Compound 4, half-maximal inhibitory concentration: > 100000 nM
Compound 4 ended at the assay's limit; the forecaster's own chance of this, stated with the estimate: 10%; at least 2.0-fold (0.30 log units) between middle value and limit.
By their numbers in this assay, from the lowest: compounds 2 and 1 (each within the scatter of the next); then compound 3. At a limit, above all of these: compound 4.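

In this assay compound 4 gives > 100000 nM, a limit of the assay and not a number: the limit of > 100000 nM in this assay, at which 1 of the 4 values shown sits.

An aromatic ring in this position therefore does not by itself go with a lower number: an at least 5.8-fold higher number from compound 2 to compound 4 (0.76 log units; beyond the scatter) and an at least 3.1-fold higher number from compound 1 to compound 4 (0.49 log units; beyond the scatter). Against ethoxy the change stays unresolved, with an at least 1.1-fold higher number from compound 3 to compound 4 (0.04 log units; that floor lies within the scatter).

From the compounds shown here alone, how far compound 4 lies past its limit stays open. So does whether a phenyl group set directly on that aromatic carbon would follow 1H-1,2,4-triazol-1-yl or (4-methylbenzyl)oxy.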